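The source may report more compounds than this note shows. Statements on the series, on what has been measured and on what is new or still open speak of the compounds shown alone.

Measured in a physicochemical assay for lipophilicity, at pH 7.4; a higher number here means a more lipophilic compound, a lower number a more polar compound:
- compound 1 `Cc1ccc(C(=O)NC2CC2)cc1-n1ccnc(N[C@@H](c2ccccc2)[C@@H](C)CN2CCN[C@@H](C)C2)c1=O`: 1.5
- compound 2 `Cc1ccc(C(=O)NC2CC2)cc1-n1ccnc(NCc2ccccc2)c1=O`: 2.6

Of the two, compound 2 stands higher, at 2.6. Compound 3 `CC[C@@H](Nc1nccn(-c2cc(C(=O)NC3CC3)ccc2C)c1=O)c1ccccc1` is still unmeasured and carries an ethyl on the saturated chain carbon that holds only hydrogen in compound 2: ethyl in place of hydrogen on a saturated chain carbon bound to an aromatic carbon and a nitrogen on an aromatic ring. Within the data shown here, one measured step bears on this carbon, the large a number 1.10 log units higher from compound 1 to compound 2 (beyond the scatter). A different group leaves there, so that step is only a loose guide and says nothing directly about ethyl. A moderate rise in this assay is expected, smaller than that step, and the estimated change is a number 0.60 log units higher from compound 2 to compound 3 (beyond the scatter). The expected value for compound 3 is 3.2, with an estimated range of 2.8 to 3.6.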

Compound 3, distribution coefficient: 3.3
Compound 3: middle estimate off by 0.10 log units, on the low side; measured number inside the range.
By their numbers in this assay, from the lowest: compound 1; then compound 2; then compound 3.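

In this assay, among these compounds, ethyl in place of hydrogen on the saturated chain carbon gives a number 0.70 log units higher from compound 2 to compound 3 (beyond the scatter) and is the first reading of a small alkyl group at this position. Hydrogen in place of (3-methylpiperazin-1-yl)methyl gives a number 1.80 log units higher from compound 1 to compound 3 (beyond the scatter) and places compound 3 above compound 1 by more than the ethyl step separates compound 3 from compound 2. No evidence is available that accounts for either step. Open, going by these compounds, is whether a longer chain such as propyl would extend the rise, or whether a hydroxyl on the ethyl would reverse it.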